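Fluoro Scan on the Amide Aryl of the Shared Core

This account rests on a few compounds, and the source may have more. Where it says the series, first, only, none or still open, it means among the compounds named here.

Compound 1 `COc1cccc(N2C(=O)COc3ccc(-c4cnc(Cl)c(NS(=O)(=O)c5ccc(F)cc5)c4)cc32)c1`, compound 2 `O=C1COc2ccc(-c3cnc4ccccc4c3)cc2N1c1ccccc1` and compound 3 `O=C1COc2ccc(-c3cccc(NS(=O)(=O)c4ccc(F)cc4)c3)cc2N1C1CCCCC1` share one core and differ in the group on the amide nitrogen and in the pendant ring. In a functional assay on HeLa cells (Homo sapiens) for antiproliferative activity, read by MTT assay, with a stated time of 72 h (a higher number here means a weaker inhibitor, a lower number a stronger inhibitor), compound 1 gives only a limit, > 40000 nM. Compound 2 also gives only a limit, > 40000 nM. Compound 2 thus stands at the limit of > 40000 nM in this assay, at which 2 of the 3 values shown sit. Compound 3 gives a number, 10800 nM. Compound 4 `O=C1COc2ccc(-c3cnc4ccccc4c3)cc2N1c1ccc(F)cc1` differs from compound 2 by fluoro in place of hydrogen on an aromatic carbon. For the measured compounds named here, no measured pair here follows this change in this assay; the expected step is none beyond the scatter, estimated as a step that the limit leaves unreadable from compound 2 to compound 4. Compound 4 is therefore expected at 50000 nM, within 20000 nM to 150000 nM, and most likely again reported only as a limit.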

Compound 4, half-maximal inhibitory concentration: 38800 nM
Beside the measured number, compound 4's estimate is 1.3-fold (0.11 log units) above it; the measured number falls inside the stated range.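

In this assay, the change from phenyl to 4-fluorophenyl yields a numerical reading rather than a limit, with an at least 1.0-fold lower number from compound 2 to compound 4 (0.01 log units; that floor lies within the scatter). This floor supports no claim of a gain from fluoro at this position. The true size of the step cannot be read because compound 2 stands at a limit of the assay: the limit of > 40000 nM in this assay, at which 2 of the 4 values shown sit.

Open, on these data alone, is whether an amine or a carboxylic acid in place of fluoro at this position would shift the number beyond the scatter. Also open, as far as these compounds go, is how any such group would read on the shared core.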